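A few compounds are considered here, and "the series" means these few. Any claim that something is new, unique, unknown or untested is made for them only; others in the source may bear on it.

Compounds measured so far in a functional assay on SW480 cells (Homo sapiens) for cytotoxicity, read by MTT assay, with a stated time of 24 h; a lower number here means a stronger inhibitor, a higher number a weaker inhibitor:
compound 1 `C=CC1=C(C(=O)NC(C)(C)C)C(c2ccc(OC)cc2)OC1` gives > 100000 nM, a limit of the assay;
compound 2 `C=CC1=C(C(=O)NCCC)C(c2ccc(F)cc2)OC1` gives > 100000 nM, a limit of the assay;
compound 3 `C=CC1=C(C(=O)NC2CCCCC2)C(c2ccc(F)cc2)OC1` gives > 100000 nM, a limit of the assay.

Compound 3 stands at the limit of this assay, and the two other values shown are limits as well, so no number places it above or below either. Going by the values given here, the one measured step, a step that the two limits leave unreadable from compound 2 to compound 3, cannot be read. The change to compound 4 `C=CC1=C(C(=O)NC(C)(C)C)C(c2ccc(F)cc2)OC1` is tert-butyl in place of cyclohexyl on an amide-type nitrogen. Among the compounds with values here, it touches the same amide-type nitrogen as that step, but that step gives no size, so no measured step says whether this change should move the value in this assay at all. Because (the limit of > 100000 nM in this assay, at which 3 of the 3 values shown sit), the expectation for compound 4 is that it too is expected to stay at the limit of this assay, with an estimated value of 200000 nM between 100000 nM and 1000000 nM. The step from compound 3 to compound 4 is accordingly expected to be a step that the limit leaves unreadable from compound 3 to compound 4.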

Compound 4, half-maximal inhibitory concentration: > 100000 nM
Compound 4: a limit, no number; the forecaster's own chance of this, stated with the estimate: 90%; the middle value lies beyond the limit too.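

In this assay compound 4 gives > 100000 nM, a limit of the assay, so its steps from compound 1, compound 2 and compound 3 cannot be read. The compounds shown leave open whether any change on the amide-type nitrogen or the aromatic carbon moves the value at all: the limit of > 100000 nM in this assay, at which 4 of the 4 values shown sit.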